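Changing the aryl group on a well-tolerated compound

A few compounds are considered here, and "the series" means these few. Any claim that something is new, unique, unknown or untested is made for them only; others in the source may bear on it.

Compound 1 `Cc1nc(C(NC(=O)C(=O)NC2CCCCCC2)C2CCCCN2)sc1CCO`: 60000 nM
Compound 2 `CC(=O)c1ccc(NC(=O)C(=O)NC(c2nc(C)c(CCO)s2)C2CCCCN2)cc1`: > 48300 nM (a limit)

These values come from an ADME assay on MT2 cells (Homo sapiens) for cytotoxicity, read by XTT assay, with a stated time of 4 days; a higher number here means that more compound is tolerated, a lower number that less compound is tolerated. Compound 2 stands at > 48300 nM, which is a limit of the assay and not a number. Compound 3 `Cc1nc(C(NC(=O)C(=O)Nc2ccc(F)c(F)c2)C2CCCCN2)sc1CCO` differs from compound 2 by 3,4-difluorophenyl in place of 4-acetylphenyl on an amide-type nitrogen, with 3,4-difluorophenyl in place of 4-acetylphenyl on an amide-type nitrogen. Within the data shown here, the only measured step that bears on this is a step that the limit leaves unreadable from compound 1 to compound 2, so it offers no size to carry over. No change beyond the scatter is therefore expected in this assay. The expected step is a step that the limit leaves unreadable from compound 2 to compound 3. The estimate for compound 3 is 55000 nM, with an expected range of 25000 nM to 120000 nM.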

Compound 3, half-maximal cytotoxic concentration: > 78200 nM
Compound 3: only a limit was reported; the forecaster's own chance of this, stated with the estimate: 55%; middle value at least 1.4-fold (0.15 log units) from the limit.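

In this assay compound 3 stands at > 78200 nM, which is a limit of the assay and not a number. Putting 3,4-difluorophenyl in place of cycloheptyl on this amide-type nitrogen gives an at least 1.3-fold higher number from compound 1 to compound 3 (0.11 log units; that floor lies within the scatter), so this change shows no loss of tolerance. The step between compound 2 and compound 3 cannot be read, as both values are limits.

On these data alone, the true values of compound 2 and compound 3 stay open. So does how a phenyl ring carrying a carboxylic acid or an amine would fare at this nitrogen.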